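Methoxy on the Core: A Fourth Variant Awaits Measurement

A few compounds are considered here, and "the series" means these few. Any claim that something is new, unique, unknown or untested is made for them only; others in the source may bear on it.

Three close relatives have been tested in a functional assay on OVCAR-3 cells (Homo sapiens) for inhibition, read by CCK-8 assay, with a stated time of 72 h, tested at 20 uM; on this read-out higher numbers stand for more inhibition of growth at the one concentration tested and lower numbers for less inhibition of growth. The parent, compound 1 `CC(C)(C)OC(=O)/C=C1/C(=O)Nc2ccccc21`, gives 59.6%. Compound 2 `CC(C)c1ccc2c(c1)/C(=C\C(=O)OC(C)(C)C)C(=O)N2` carries an isopropyl group on the aromatic ring and gives 59.7%, while compound 3 `CCCCc1ccc2c(c1)/C(=C\C(=O)OC(C)(C)C)C(=O)N2` carries a butyl group there and gives 60.2%. The three numbers sit so close together that none of the compounds can be called weaker or stronger than another; compound 1 simply serves as the unsubstituted reference from which the other two are derived.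

Compound 4 `COc1ccc2c(c1)NC(=O)/C2=C/C(=O)OC(C)(C)C` is the next variant. Compared with compound 1 it differs as follows: methoxy in place of hydrogen on an aromatic carbon. For the measured compounds named here, the steps that bear on this change are the earlier additions at the same kind of position: a number 0.1 percentage points higher from compound 1 to compound 2 (within the scatter) and a number 0.6 percentage points higher from compound 1 to compound 3 (within the scatter). Both lie within the scatter, and so does a number 0.5 percentage points higher from compound 2 to compound 3 (within the scatter). Adding a small group to this ring has so far left the read-out in this assay essentially unchanged, so a similar outcome is the natural expectation for the methoxy group, though a group with an oxygen has not yet been tried here. Compound 4 is therefore expected to give 60%, with a range from 50% to 70%. The expected step of a number 0.4 percentage points higher from compound 1 to compound 4 (within the scatter) should stay within the scatter.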

Compound 4, percent growth inhibition at one concentration: 57.9%
Compound 4: middle estimate off by 2.1 percentage points, on the high side; the range from low to high includes it.
By their numbers in this assay, from the lowest: compounds 4, 1, 2 and 3 (each within the scatter of the next).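

With methoxy, the aromatic ring of the shared core carries a group containing oxygen for the first time among these compounds, where compounds 2 and 3 carry only the carbon chains isopropyl and butyl. In this assay this change gives a number 1.7 percentage points lower from compound 1 to compound 4 (within the scatter) and so stays inside the usual spread of repeated measurements, which means that introducing oxygen in this group, at a place on the ring that is meta to a fused ring and para to a fused ring, does not separate compound 4 from the unsubstituted compound 1. No measurement shown here gives a reason why the read-out stays so flat across these changes.

All four compounds lie within the scatter of their neighbours at a single tested concentration, so the compounds shown do not reveal any ring substituent that truly moves growth inhibition, nor whether small real differences are hidden at this one concentration. On these data alone, whether an amine, a carboxylic acid or a chlorine on the ring would shift the number beyond the scatter stays open, and so does the effect of replacing the tert-butyl ester, which all four compounds share.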